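The source may hold more compounds than are shown below. What is called first, only, known or untested is meant among the compounds shown, and "the series" means these compounds.

Measured so far in an ADME assay on MT4 cells (Homo sapiens) for cytotoxicity, read by MTT assay, with a stated time of 5 days; on this read-out lower numbers stand for higher toxicity in this test and higher numbers for lower toxicity in this test:

Compound 1 `COc1cc2nc(SCC(=O)Nc3ccc([N+](=O)[O-])cc3)nc(Nc3c(C)cc(/C=C/C#N)cc3C)c2cc1OC`: in this assay compound 1 gives only the limit > 219000 nM, which is a limit of the assay and not a number.
Compound 2 `COc1cc2nc(SCC(=O)Nc3ccc(C)cc3)nc(Nc3c(Cl)cc(/C=C/C#N)cc3Cl)c2cc1OC`: in this assay compound 2 gives 2540 nM.
Compound 3 `COc1cc2nc([S+]([O-])CC(=O)Nc3cccc(F)c3)nc(Nc3c(Cl)cc(/C=C/C#N)cc3Cl)c2cc1OC`: in this assay compound 3 gives 9550 nM.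

Compound 3 thus stands at the highest of the two numbers obtained in this assay, that is, it is the less toxic of the two measured to a number. Its nearest neighbour, compound 2, sits at a lower number, and the gap between them is beyond the usual scatter of repeated measurements. The third value, that of compound 1, is a limit and not a number: the limit of > 219000 nM in this assay, at which 1 of the 3 values shown sits.

Compound 4 `COc1cc2nc([S+]([O-])CC(=O)Nc3c(C)cc(C)cc3C)nc(Nc3c(Cl)cc(/C=C/C#N)cc3Cl)c2cc1OC` differs from compound 3 in a single place: 2,4,6-trimethylphenyl in place of 3-fluorophenyl on an amide-type nitrogen. Going by the values given here, no pair of measured compounds isolates this particular change, so nothing measured here points firmly to one direction. The expectation is a small shift toward a lower number in this assay, a 1.4-fold lower number from compound 3 to compound 4 (0.13 log units; within the scatter), of a size that may well stay within the scatter. Compound 4 is therefore estimated at 7000 nM, with a likely range from 2500 nM to 25000 nM.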

Compound 4, half-maximal cytotoxic concentration: 8870 nM
Compound 4: the middle estimate sits 1.3-fold (0.10 log units) below what was measured; the measured number falls inside the stated range.
By their numbers in this assay, from the lowest: compound 2; then compounds 4 and 3 (each within the scatter of the next). At a limit, above all of these: compound 1.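

In this assay, going by these compounds alone, putting 2,4,6-trimethylphenyl in place of 3-fluorophenyl on an amide-type nitrogen gives a 1.1-fold lower number from compound 3 to compound 4 (0.03 log units; within the scatter), the first comparison here in which only one place in the molecule differs. Going from 7 heavy atoms to 9 and losing the fluorine therefore leaves compound 3 and compound 4 indistinguishable in this test, although this holds only for this one pair and does not establish a rule for other groups at this position. Nothing measured here explains why the two compounds cannot be told apart.

Going by these compounds, it remains open whether the same would hold for a group of a different kind on this nitrogen, such as a phenyl ring carrying a carboxylic acid, a phenyl ring carrying an amine, or a longer alkyl chain in place of the ring. Compound 2 differs from compound 3 in more than one place, so the contribution of each of those places to their values also remains unresolved.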